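Side-chain change from compound 3 to compound 4

The compounds below may be only part of what the source reports. "The series", "measured", "known", "first", "only" and "open" are said of these compounds alone.

Measured in a functional assay on B16-F10 cells (Mus musculus) for antiproliferative activity, read by CCK-8 assay, with a stated time of 48 h; a lower number here means a stronger inhibitor, a higher number a weaker inhibitor:
- compound 1 `COc1ccc(/C=C\c2cc(OC)c(OC)c(OC)c2)cc1OCc1ccc(CNCCO)cc1`: 6600 nM
- compound 2 `COc1ccc(/C=C\c2cc(OC)c(OC)c(OC)c2)cc1OCc1ccc(CN2CCCCC2C(=O)NCCNC(=O)OC(C)(C)C)cc1`: 4700 nM
- compound 3 `COc1ccc(/C=C\c2cc(OC)c(OC)c(OC)c2)cc1OCc1ccc(CO)cc1`: 6600 nM

Compound 1 stands level with compound 3 at 6600 nM, and compound 2 lies within the scatter of both.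

The next compound is compound 4 `COc1ccc(/C=C\c2cc(OC)c(OC)c(OC)c2)cc1OCc1ccc(CN[C@H](C(=O)O)[C@@H](C)O)cc1`, which differs from compound 3 as follows: (1-carboxy-2-hydroxypropyl)amino in place of hydroxy on a saturated chain carbon bound to an aromatic carbon. In words, hydroxymethyl becomes ((1-carboxy-2-hydroxypropyl)amino)methyl.

For the measured compounds named here, the one measured step at this place is no change at the digits printed from compound 1 to compound 3 (within the scatter), with hydroxy in place of (2-hydroxyethyl)amino on a saturated chain carbon bound to an aromatic carbon. Compound 2, which has a different amino group on that carbon, gives 4700 nM, so a second change at this place also stays within the scatter of compound 3. Going by the values given here, no measured compound carries a carboxy group, so the data do not test that part of the change, and the range below is set wide.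

The estimated change in this assay is a 1.1-fold higher number from compound 3 to compound 4 (0.03 log units; within the scatter), so no step beyond the scatter is expected. For compound 4 the estimated value is 7000 nM, with an expected range of 3000 nM to 20000 nM.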

Compound 4, half-maximal inhibitory concentration: 5400 nM
Compound 4: the middle estimate sits 1.3-fold (0.11 log units) above what was measured; the range from low to high includes it.
By their numbers in this assay, from the lowest: compounds 2, 4, 1 and 3 (each within the scatter of the next).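

In this assay, (1-carboxy-2-hydroxypropyl)amino in place of hydroxy on the saturated chain carbon bound to an aromatic carbon gives a 1.2-fold lower number from compound 3 to compound 4 (0.09 log units; within the scatter) and so brings no step beyond the scatter, even though the entering group carries a carboxy group and two defined stereocentres. Read on the amine nitrogen, 1-carboxy-2-hydroxypropyl in place of 2-hydroxyethyl gives a 1.2-fold lower number from compound 1 to compound 4 (0.09 log units; within the scatter) and likewise stays within the scatter, so the carboxy group, untested by the earlier compounds, leaves the number where hydroxy and (2-hydroxyethyl)amino had it. No supporting data bear on why this position responds so little to these changes.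

On these data alone, it remains open whether a methyl ester of the carboxylic acid, a primary amine or a longer chain ending in a carboxylic acid would give a step beyond the scatter at this carbon. The other stereoisomers of the 1-carboxy-2-hydroxypropyl group also remain open, so the compounds shown say nothing on whether its two stereocentres matter in this assay.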